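Swapping the thiophene substituent on a fused-ring growth inhibitor

A few compounds are considered here, and "the series" means these few. Any claim that something is new, unique, unknown or untested is made for them only; others in the source may bear on it.

Measured so far:
compound 1 `Cc1cc(-c2nc3sc(C)cn3c2/C=N/NC(=N)N)c(C)s1`: 4790 nM
compound 2 `Cc1cc(-c2nc3sccn3c2/C=N/NC(=N)N)c(C)s1`: 13800 nM

In a functional assay on cells (Cancer cell lines, Homo sapiens) for inhibition (on this read-out lower numbers stand for stronger inhibition of growth and higher numbers for weaker inhibition of growth), compound 1 gives 4790 nM, the lowest of the two numbers, and compound 2 gives 13800 nM. Within the data shown here, the only step so far, a 2.9-fold higher number from compound 1 to compound 2 (0.46 log units; beyond the scatter), shows that taking away a methyl group on the shared core weakens growth inhibition modestly.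

Compound 3 `Cc1cn2c(/C=N/NC(=N)N)c(-c3cccs3)nc2s1` keeps that methyl but changes the attached ring: thiophen-2-yl in place of 2,5-dimethylthiophen-3-yl on an aromatic carbon. Among the measured compounds shown here, no measured step addresses this ring, so the expectation rests loosely on the one step available, where loss of a methyl raised the number. Here two methyl groups leave and the attachment point shifts, so a somewhat higher number is expected in this assay, perhaps a step of a 1.9-fold higher number from compound 1 to compound 3 (0.27 log units; within the scatter) relative to compound 1, though the direction is uncertain.

Compound 3 is therefore estimated at 9000 nM, with a range from 3000 nM to 30000 nM.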

Compound 3, concentration for 50% growth inhibition: 3020 nM
Estimate against measurement, compound 3: 3.0-fold (0.47 log units) above, within the range that was stated.
By their numbers in this assay, from the lowest: compounds 3 and 1 (each within the scatter of the next); then compound 2.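

Putting thiophen-2-yl in place of 2,5-dimethylthiophen-3-yl on this aromatic carbon of the shared core gives a 1.6-fold lower number from compound 1 to compound 3 (0.20 log units; within the scatter) in this assay, so the two compounds cannot be told apart on this read-out. The attached ring can therefore lose both methyl groups and change its attachment point without a change beyond the scatter, whereas the methyl on the core gave a step beyond it, a 2.9-fold higher number from compound 1 to compound 2 (0.46 log units; beyond the scatter). No available evidence says what lies behind this result.

From the compounds shown here alone, this single swap changes the methyl groups and the attachment point together, so the part each plays stays open, and a comparison with thiophen-3-yl could help separate them. Also unknown is how this position would respond to a different kind of group, such as phenyl, or to a thiophene ring carrying an amine or a carboxylic acid.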